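This account rests on a few compounds, and the source may have more. Where it says the series, first, only, none or still open, it means among the compounds named here.

Among the measured compounds shown here, in an ADME assay on MDBK cells (Bos taurus) for cytotoxicity (a higher number here means that more compound is tolerated, a lower number that less compound is tolerated), compound 3 `Ic1ccc(Cn2ccc3nc(-c4ccccc4)nc-3c2)cc1` gives 22000 nM, the only actual number so far. Compound 1 `COc1cccc(Cn2ccc3nc(-c4ccccc4)nc-3c2)c1` reads > 100000 nM, which is a limit. Compound 2 `N#Cc1ccccc1Cn1ccc2nc(-c3ccccc3)nc-2c1` reads > 100000 nM, also a limit. Compound 4 `CC(C)=CCn1ccc2nc(-c3ccccc3)nc-2c1` differs from compound 3 as follows: 2-methylprop-1-en-1-yl in place of 4-iodophenyl on a saturated chain carbon bound to an aromatic nitrogen. For the measured compounds named here, the steps that bear on this change are an at least 4.5-fold lower number from compound 1 to compound 3 (0.65 log units; beyond the scatter) and an at least 4.5-fold lower number from compound 2 to compound 3 (0.65 log units; beyond the scatter). Both lie beyond the scatter and both end at compound 3 with its 4-iodophenyl, so a higher number is expected once that group leaves. Neither step tests 2-methylprop-1-en-1-yl itself, so only a modest rise in this assay is expected, and a limit reading is possible. The expected step is a 2.7-fold higher number from compound 3 to compound 4 (0.44 log units; beyond the scatter). For compound 4 the estimated value is 60000 nM, with an expected range of 20000 nM to 150000 nM.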

Compound 4, half-maximal cytotoxic concentration: > 100000 nM
Compound 4 ended at the assay's limit; the forecaster's own chance of this, stated with the estimate: 45%; middle value at least 1.6-fold (0.22 log units) away from the limit.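

In this assay, 2-methylprop-1-en-1-yl in place of 4-iodophenyl gives an at least 4.5-fold higher number from compound 3 to compound 4 (0.65 log units; beyond the scatter), so the move away from 4-iodophenyl need not keep an aromatic ring for the number to rise. Compound 4 reads > 100000 nM, which is a limit. The steps among compound 1, compound 2 and compound 4 cannot be read, and no order can be set among them: the limit of > 100000 nM in this assay, at which 3 of the 4 values shown sit.

On these data alone, whether the iodine or the whole 4-iodophenyl lowers the number stays open. So does the reading of an unsubstituted benzyl group, or of a longer chain carrying an amine or a carboxylic acid, at this place.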